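Chalcone series: methoxyphenyl replaces nitrophenyl on the five-membered ring

The source may report more compounds than this note shows. Statements on the series, on what has been measured and on what is new or still open speak of the compounds shown alone.

Compound 1 `CC1(C)Cc2c(ccc(C(=O)/C=C/c3cn(-c4ccccc4)nc3-c3cccc([N+](=O)[O-])c3)c2OCc2ccccc2)O1` is the reference point. In a functional assay on NCI-H460 cells (Homo sapiens) for antiproliferative activity, read by MTT assay, with a stated time of 48 h (on this read-out higher numbers stand for weaker inhibition and lower numbers for stronger inhibition), compound 1 gives > 100000 nM, which is a limit of the assay and not a number. Compound 2 `CC1(C)Cc2c(ccc(C(=O)/C=C/c3ccc(Br)cc3)c2OCc2ccccc2)O1` belongs to the same series. In this assay compound 2 gives > 100000 nM, again a limit rather than a number. Among the measured compounds shown here, compound 1 thus stands where the only other value shown also stands, as the limit of > 100000 nM in this assay, at which 2 of the 2 values shown sit, records; no step between measured compounds is available, and no direction can be read from the two values.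

Compound 3 `COc1ccc(-c2nn(-c3ccccc3)cc2/C=C/C(=O)c2ccc3c(c2OCc2ccccc2)CC(C)(C)O3)cc1` differs from compound 1 in one place: 4-methoxyphenyl in place of 3-nitrophenyl on an aromatic carbon of a five-membered aromatic ring with 2 nitrogen, next to the ring nitrogen and next to the ring atom that bears a large group. With both measured values sitting at the limit (the limit of > 100000 nM in this assay, at which 2 of the 2 values shown sit), the expectation in this assay is no step beyond the scatter, in either direction. The step expected is a step that the limit leaves unreadable from compound 1 to compound 3. In this assay compound 3 is estimated at 150000 nM, with a range from 50000 nM to 500000 nM, and most probably reported only as a limit.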

Compound 3, half-maximal inhibitory concentration: > 100000 nM
Compound 3 was reported as a limit; the forecaster's own chance of this, stated with the estimate: 80%; the middle value is on the limit's open side.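

No step can be read from compound 1 to compound 3 in this assay, because both compounds are reported only as limits: the limit of > 100000 nM in this assay, at which 3 of the 3 values shown sit.

The compounds shown leave open whether any change to the shared core gives a measurable value in this assay, and what 4-methoxyphenyl in place of 3-nitrophenyl does to the read-out.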